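Methoxy for chloro across two cores in an aromatase series

This account rests on a few compounds, and the source may have more. Where it says the series, first, only, none or still open, it means among the compounds named here.

Compound 1 `Fc1ccc2c(Cn3ccnc3)c(-c3ccc(Cl)cc3)[nH]c2c1` and compound 2 `COc1ccc(-c2[nH]c3cc(F)ccc3c2Cn2ccnc2)cc1` share one core; compound 3 `Fc1ccc(-c2[nH]c3cc(Cl)ccc3c2Cn2cncn2)cc1` and the unmeasured compound 4 `COc1ccc2c(Cn3cncn3)c(-c3ccc(F)cc3)[nH]c2c1` share another. In an assay on isolated protein for inhibition of Aromatase (Homo sapiens), read by ELISA, using NADPH, with a stated time of 24 h (on this read-out lower numbers stand for stronger inhibition and higher numbers for weaker inhibition), compound 1 gives 82.9 nM, compound 2 gives 36.1 nM and compound 3 gives 96.9 nM. The difference between the two cores is not broken down here.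

The measured change is methoxy in place of chloro on an aromatic carbon, and it produced a 2.3-fold lower number from compound 1 to compound 2 (0.36 log units; beyond the scatter). The change planned for compound 4 is methoxy in place of chloro on an aromatic carbon. It is the same kind of change, not the same: in the first case the place is "on an aromatic carbon of a six-membered aromatic ring of carbon only; para to a large group", in the second it is "part of a fused or bridged system of two rings; meta to a fused ring; para to a fused ring".

Among the compounds with values here, for compound 4 a step of about a 1.8-fold lower number from compound 3 to compound 4 (0.25 log units; within the scatter) in this assay is expected, resting on the single measured instance of the change and discounted because a 2.3-fold lower number from compound 1 to compound 2 (0.36 log units; beyond the scatter) was measured at a different place. Compound 4 is therefore estimated at 55 nM, with a range from 20 nM to 160 nM.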

Compound 4, half-maximal inhibitory concentration: 238 nM
The estimate for compound 4 lay 4.3-fold (0.64 log units) below the measured number; measured number above the stated range.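

In this assay, methoxy in place of chloro on an aromatic carbon gave a 2.5-fold higher number from compound 3 to compound 4 (0.39 log units; beyond the scatter), so the direction of the step did not carry over from one core to the other, as the two steps set side by side show: the same change on two cores in this assay, a 2.3-fold lower number (0.36 log units; beyond the scatter) from compound 1 to compound 2 and a 2.5-fold higher number (0.39 log units; beyond the scatter) from compound 3 to compound 4, 5.6-fold (0.75 log units) apart, beyond the scatter of two such steps

The change therefore cannot be treated as a fixed gain in this series, and a measured step on one core is a poor guide to the same kind of step on the other. Core and place change together in these two pairs, so the data do not show which of the two governs the reversal, and two pairs give no rule for any further core.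

From the compounds shown here alone, what remains open is whether methoxy in place of chloro keeps its direction at each place when the rest of the molecule is held fixed. Also open, going by these compounds, is how the place held by the chloro of compound 3 responds to other groups, such as an amine or a nitrile.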